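The source may hold more compounds than are shown below. What is called first, only, known or untested is meant among the compounds shown, and "the series" means these compounds.

Compound 1, `O=C(Nc1ccc(Oc2ccnc3[nH]ccc23)cc1)c1cn(-c2ccc(Br)cc2)c2ccccc2c1=O`, gives 220 nM in a functional assay on HepG2 cells (Homo sapiens) for inhibition, read by MTT assay, with a stated time of 72 h; a lower number here means a stronger inhibitor, a higher number a weaker inhibitor.
Compound 2, `O=C(Nc1ccc(Oc2ccnc3[nH]ccc23)cc1)c1cn(-c2ccc(Br)cc2F)c2ccccc2c1=O`, gives 790 nM in this assay.
Compound 3, `Cn1ccc2c(Oc3ccc(NC(=O)c4cn(-c5ccccc5)c5ccccc5c4=O)cc3F)ccnc21`, gives 2170 nM in this assay.

Compound 4, `Cn1ccc2c(Oc3ccc(NC(=O)c4cn(-c5ccc(F)cc5)c5ccccc5c4=O)cc3F)ccnc21`, has not yet been measured. It is built on the core of compound 3, and how that core differs from the core of compound 1 is not broken down here; what the numbers show is that compound 3 gives the highest number of the three, beyond the scatter against both compound 1 and compound 2.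

The change from compound 1 to compound 2 is fluoro in place of hydrogen on an aromatic carbon. In this assay that step was a 3.6-fold higher number from compound 1 to compound 2 (0.56 log units; beyond the scatter). The change from compound 3 to compound 4 is fluoro in place of hydrogen on an aromatic carbon. The two are the same kind of change, but not the same: in compound 2 the fluoro sits ortho to a large group and meta to a bromo group, while in compound 4 it sits para to a large group, on a ring that carries no bromo group. Within the data shown here, the earlier step therefore gives only a loose guide, and a more moderate move is expected here, since the one measured example, the step from compound 1 to compound 2, rests on a different place. For compound 4 the expected step is a 1.2-fold higher number from compound 3 to compound 4 (0.08 log units; within the scatter). Compound 4 is thus expected to give 2600 nM, most likely between 1200 nM and 5500 nM.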

Compound 4, half-maximal inhibitory concentration: 2010 nM
Beside the measured number, compound 4's estimate is 1.3-fold (0.11 log units) above it; the measured number falls inside the stated range.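

On the core of compound 3, going from phenyl to 4-fluorophenyl made no readable difference in this assay, with a 1.1-fold lower number from compound 3 to compound 4 (0.03 log units; within the scatter). Swapping a hydrogen for fluoro on an aromatic carbon therefore did not carry the same result from one core to the other, as the earlier step and the new one differ by more than the scatter: the same change on two cores in this assay, a 3.6-fold higher number (0.56 log units; beyond the scatter) from compound 1 to compound 2 and a 1.1-fold lower number (0.03 log units; within the scatter) from compound 3 to compound 4, 3.9-fold (0.59 log units) apart, beyond the scatter of two such steps. This does not show that the core alone sets the outcome, since only one pair per core is shown, the fluoro does not occupy the same place in the two pairs, and compound 2 carries a bromo group that compound 4 lacks, so these differences cannot be told apart and no general rule for the series follows.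

Still open, going by these compounds, is whether a fluoro placed identically on both cores would give matching steps, which would separate the effect of the core from that of the place. Also open, on these data alone, is whether a different group on that same aromatic carbon of the core of compound 3, such as a methoxy group, an amine or a carboxylic acid, would move the number where fluoro did not.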